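Arylsulfonyl indazoles: para-substituent swap on the sulfonyl aryl

The source may hold more compounds than are shown below. What is called first, only, known or untested is meant among the compounds shown, and "the series" means these compounds.

Measured compounds:
- compound 1, `Cc1ccc(S(=O)(=O)c2n[nH]c3ccc(N4CCN(C)CC4)cc23)cc1`: 100%
- compound 2, `CCCn1nc(S(=O)(=O)c2cccc3ccccc23)c2cc(N3CCNCC3)ccc21`: 99%

In a functional assay on HeLa cells for antagonist activity at 5-hydroxytryptamine receptor 6 (Homo sapiens) (a higher number here means a larger maximal response, a lower number a smaller maximal response), compound 1 gives 100%, the highest of the two numbers recorded. In the same assay compound 2 gives 99%, which lies within the scatter of compound 1, so the two are not distinguishable on this read-out. Compound 3, `CN1CCN(c2ccc3[nH]nc(S(=O)(=O)c4ccc(F)cc4)c3c2)CC1`, has not yet been measured in this assay. It differs from compound 1 in one place: fluoro in place of methyl on an aromatic carbon. Going by the values given here, no step between measured compounds is available for this change, and the two recorded values leave no room for an increase in maximal response. The step of a number 2 percentage points lower from compound 1 to compound 3 (within the scatter) is therefore expected to stay within the scatter, with no shift in either direction that could be read as real. Compound 3 is expected to give 98% in this assay, with a range from 86% to 106%.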

Compound 3, largest response reached (reported as Imax), in percent of the reference or control that the assay uses: 98%
Compound 3: middle estimate and measured number agree at the digits printed; measured number inside the range.
By their numbers in this assay, from the lowest: compounds 3, 2 and 1 (each within the scatter of the next).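

In this assay, going by these compounds alone, the series now has a step that isolates this position: a number 2 percentage points lower from compound 1 to compound 3 (within the scatter) is the only single-place comparison available. On the ring carrying the sulfonyl group, at the carbon para to a large group, 4-methylphenyl and 4-fluorophenyl therefore cannot be told apart on maximal response, so this exchange of one heavy atom for another gives no readable effect on this read-out. No measurement bearing on why this is so is available.

As far as these compounds go, what a substituent of a different kind at this carbon would do remains open, for example a methoxy group, a carboxylic acid, a primary amine or a longer alkyl chain. Also open, from the compounds shown here alone, is whether any group here can separate from compound 1 by more than the scatter in this assay, or whether the position tolerates substitution generally.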